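The source may hold more compounds than are shown below. What is called first, only, known or untested is meant among the compounds shown, and "the series" means these compounds.

Measured so far:
compound 1 `c1ccc(-c2cn3ccnc3c(-c3ccc4ncn(C5CCCCC5)c4c3)n2)cc1`: 7.52%
compound 2 `Clc1ccc(-c2cn3ccnc3c(-c3ccc4ncn(C5CCCCC5)c4c3)n2)cc1`: 6.14%

In a functional assay on SK-OV-3 cells (Homo sapiens) for inhibition, read by sulforhodamine B assay, with a stated time of 48 h, tested at 10 uM (a lower number here means less inhibition, a higher number more inhibition at the concentration tested (going by the name of the read-out)), compound 2 stands lowest of the two numbers, with compound 1 nearest (a number 1.4 percentage points lower from compound 1 to compound 2 (within the scatter)). Compound 3 `COc1ccccc1-c1cn2ccnc2c(-c2ccc3ncn(C4CCCCC4)c3c2)n1` differs from compound 2 by 2-methoxyphenyl in place of 4-chlorophenyl on an aromatic carbon. Within the data shown here, the single measured step, a number 1.4 percentage points lower from compound 1 to compound 2 (within the scatter), concerns a different change and lies within the scatter, so it bears only loosely on this one; no measured pair addresses the entering group. Both measured numbers are low, and no step beyond the scatter is expected here. Compound 3 is therefore estimated at 8%, range 0% to 25%, a step of a number 1.9 percentage points higher from compound 2 to compound 3 (within the scatter).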

Compound 3, a percentage reported as inhibition, at one concentration (the size of the read-out at that concentration, not a potency): 10.6%
Compound 3: the middle estimate sits 2.6 percentage points below what was measured; the measured number falls inside the stated range.
By their numbers in this assay, from the lowest: compounds 2, 1 and 3 (each within the scatter of the next).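

In this assay, 2-methoxyphenyl in place of 4-chlorophenyl on this aromatic carbon gives a number 4.5 percentage points higher from compound 2 to compound 3 (within the scatter), and methoxy in place of hydrogen on the same phenyl gives a number 3.1 percentage points higher from compound 1 to compound 3 (within the scatter), so neither step separates the compounds. Three different phenyl groups at this position, one of them carrying a hydrogen-bond acceptor, therefore cannot be told apart in this read-out. No supporting data bear on this result.

Still open, from the compounds shown here alone, is whether an amine or a carboxylic acid on this phenyl would give a step beyond the scatter. Going by these compounds, the rest of the core is the same in all three compounds, so the effect of changes elsewhere remains unknown.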